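A few compounds are considered here, and "the series" means these few. Any claim that something is new, unique, unknown or untested is made for them only; others in the source may bear on it.

Series notes. Compound 2 `Cc1cc(-c2ccc(Cl)cc2)cc(C)c1Nc1ccnc(Nc2ccc(C#N)cc2)n1` gives 4190 nM in an ADME assay on MT4 cells (Homo sapiens) for cytotoxicity, read by MTT assay, with a stated time of 4 days; on this read-out higher numbers stand for lower toxicity in this test and lower numbers for higher toxicity in this test. Among the three measured compounds, compound 2 stands highest: compound 3 `Cc1cc(-c2cccc(Cl)c2)cc(C)c1Nc1ccnc(Nc2ccc(C#N)cc2)n1` gives 2160 nM, and the step of a 1.9-fold lower number from compound 2 to compound 3 (0.29 log units; within the scatter) lies within scatter, while compound 1 `Cc1cc(-c2cccc(C#N)c2)cc(C)c1Nc1ccnc(Nc2ccc(C#N)cc2)n1` gives 920 nM, and the step of a 4.6-fold higher number from compound 1 to compound 2 (0.66 log units; beyond the scatter) lies beyond scatter. The remaining measured step, a 2.3-fold higher number from compound 1 to compound 3 (0.37 log units; beyond the scatter), is also beyond scatter.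

Compound 4 `COc1cccc(-c2cc(C)c(Nc3ccnc(Nc4ccc(C#N)cc4)n3)c(C)c2)c1` differs from compound 2 in one place: 3-methoxyphenyl in place of 4-chlorophenyl on an aromatic carbon. Going by the values given here, two measured steps bear on this. The move from 4-chlorophenyl to 3-chlorophenyl, a 1.9-fold lower number from compound 2 to compound 3 (0.29 log units; within the scatter), stayed within scatter, so the placement alone gives no reason to expect a shift. Among the compounds with values here, the exchange of chloro in place of cyano on an aromatic carbon, a 2.3-fold higher number from compound 1 to compound 3 (0.37 log units; beyond the scatter), was modest and beyond scatter, showing that the group on this carbon can move the number; no measured pair covers methoxy. The expected step of a 1.4-fold lower number from compound 2 to compound 4 (0.15 log units; within the scatter) is therefore small, with a somewhat lower number not excluded. Compound 4 is estimated at 3000 nM in this assay, with a range of 1200 nM to 7500 nM.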

Compound 4, half-maximal cytotoxic concentration: 2990 nM
Compound 4: the middle estimate sits 1.0-fold (0.00 log units) above what was measured; the measured number falls inside the stated range.
By their numbers in this assay, from the lowest: compound 1; then compounds 3, 4 and 2 (each within the scatter of the next).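

Working from this assay, the 3-methoxyphenyl group of compound 4 cannot be told apart from either chlorophenyl group: a 1.4-fold lower number from compound 2 to compound 4 (0.15 log units; within the scatter) and a 1.4-fold higher number from compound 3 to compound 4 (0.14 log units; within the scatter) both stay within the scatter. The step of a 3.3-fold higher number from compound 1 to compound 4 (0.51 log units; beyond the scatter) lies beyond the scatter, so among these four compounds compound 1, with its 3-cyanophenyl group, now stands apart from all three others, none of which goes against this. Nothing measured here offers an explanation for that separation.

Whether this separation belongs to the nitrile itself or to its placement on the ring remains open, as 4-cyanophenyl and 4-methoxyphenyl groups do not appear among these compounds. Also open, from the compounds shown here alone, is how an amine, a carboxylic acid or a longer alkoxy chain on this ring would shift the number.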